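The source may hold more compounds than are shown below. What is called first, only, known or untested is meant among the compounds shown, and "the series" means these compounds.

Measured compounds:
compound 1 `CCCCC(CC)C(=O)Nc1ccc2ccn(Cc3ccc(C(=O)NS(=O)(=O)c4ccccc4C)cc3OC)c2c1` – 8.9 in a functional assay (trachea) for antagonist activity, with Cavia porcellus as the target; on this read-out higher numbers stand for higher potency (the scale is a negative logarithm) and lower numbers for lower potency
compound 2 `COc1cc(C(=O)NS(=O)(=O)c2cccs2)ccc1Cn1ccc2ccc(NC(=O)CC3CCCC3)cc21` – 9.6
compound 3 `COc1cc(C(=O)NS(=O)(=O)c2ccccc2Cl)ccc1Cn1ccc2ccc(NC(=O)CC3CCCC3)cc21` – 9.8

Compound 3 gives the highest of the three numbers. Compound 2 stands nearest, and the step of a number 0.20 log units higher from compound 2 to compound 3 (within the scatter) is within the scatter, so the two cannot be ordered. Going by the values given here, compound 1 stands furthest, and its number is beyond the scatter below that of compound 3; no single-point step is set out between these two, as they differ in the sulfonyl aryl and in the amide.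

Compound 4 `COc1cc(C(=O)NS(=O)(=O)c2ccccc2C)ccc1Cn1ccc2ccc(NC(=O)CC3CCCC3)cc21` differs from compound 3 by methyl in place of chloro on an aromatic carbon. Among the compounds with values here, no measured step shows exactly this exchange. Within the data shown here, the only step at the sulfonyl aryl, a number 0.20 log units higher from compound 2 to compound 3 (within the scatter), is small. Compound 1 carries the same 2-methylphenyl sulfonyl as compound 4 but a different amide, so its number bears on compound 4 only loosely.

The step of a number 0.20 log units lower from compound 3 to compound 4 (within the scatter) is therefore expected to stay within the scatter. Compound 4 is estimated at 9.6, with a range from 9 to 10.1.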

Compound 4, negative logarithm of the antagonist equilibrium constant: 9.9
For compound 4 the middle estimate is 0.30 log units below the measured one; low and high end bracket the measured number.
By their numbers in this assay, from the lowest: compound 1; then compounds 2, 3 and 4 (each within the scatter of the next).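

In this assay, methyl in place of chloro on an aromatic carbon gives a number 0.10 log units higher from compound 3 to compound 4 (within the scatter) and a swap of the aryl group on the sulfonyl sulfur gives a number 0.30 log units higher from compound 2 to compound 4 (within the scatter) so the three sulfonyl aryl groups carried with the cyclopentylmethyl amide cannot be ordered. The amide is the one place here where a single exchange lies beyond the scatter: cyclopentylmethyl in place of 1-ethylpentyl on a carbonyl carbon gives a number 1.00 log units higher from compound 1 to compound 4 (beyond the scatter) and this rests on one pair only. No measurement shown offers an explanation for these results.

On these data alone, what a carboxylic acid or an amine in place of methyl on the aromatic carbon would give remains open, as does an unsubstituted phenyl on the sulfonyl sulfur. On the carbonyl carbon, a longer chain or cyclohexylmethyl also remains unplaced.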